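The source may report more compounds than this note shows. Statements on the series, on what has been measured and on what is new or still open speak of the compounds shown alone.

Working notes on the ester series. For the measured compounds named here, the shared core is that of compound 1, `CC/C=C\C[C@H]1C(=O)C=C[C@H]1CC(=O)OCCC`; in an ADME assay on RAW264.7 cells (Mus musculus) for cytotoxicity, read by MTT assay, with a stated time of 24 h (a lower number here means that less compound is tolerated, a higher number that more compound is tolerated), compound 1 gives 35 uM, the second highest of the three numbers so far. Compound 2, `CC/C=C\C[C@H]1C(=O)C=C[C@H]1CC(=O)OCc1ccccc1`, gives 31 uM, and compound 3, `CC/C=C\C[C@H]1C(=O)C=C[C@H]1CC(=O)OCCOCCO`, gives 166 uM. The step of a 1.1-fold lower number from compound 1 to compound 2 (0.05 log units; within the scatter) lies within the scatter, whereas a 4.7-fold higher number from compound 1 to compound 3 (0.68 log units; beyond the scatter) and a 5.4-fold higher number from compound 2 to compound 3 (0.73 log units; beyond the scatter) are modest steps beyond it. Compound 4, `CC/C=C\C[C@H]1C(=O)C=C[C@H]1CC(=O)OC(C)(C)C`, differs from compound 1 by tert-butyl in place of propyl on an oxygen next to a carbonyl group. This exchanges propyl for tert-butyl and brings in no 2-hydroxyethoxy as in compound 3, so the comparison that bears on it is the within-scatter step between compound 1 and compound 2. No step beyond the scatter is therefore expected in this assay. Compound 4 is expected to give about 40 uM, in the range 20 uM to 80 uM, a step of a 1.1-fold higher number from compound 1 to compound 4 (0.06 log units; within the scatter).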

Compound 4, half-maximal toxic concentration: 33 uM
Compound 4: middle estimate off by 1.2-fold (0.08 log units), on the high side; low and high end bracket the measured number.
By their numbers in this assay, from the lowest: compounds 2, 4 and 1 (each within the scatter of the next); then compound 3.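

In this assay the steps of a 1.1-fold lower number from compound 1 to compound 4 (0.03 log units; within the scatter) and a 1.1-fold higher number from compound 2 to compound 4 (0.03 log units; within the scatter) show that tert-butyl on this oxygen reads the same as propyl and benzyl, so a branched group joins a straight chain and an aryl-bearing one within the scatter. For the compounds shown here, the step of a 5.0-fold lower number from compound 3 to compound 4 (0.70 log units; beyond the scatter) leaves 2-(2-hydroxyethoxy)ethyl as the only group here standing beyond the scatter from all the others. Open, going by these compounds, is whether that separation follows the hydroxy group or the ether oxygen, and how a 2-aminoethyl group or a chain ending in a carboxylic acid would read at this oxygen. No measurement on hand bears on why the groups separate in this way.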